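The compounds below may be only part of what the source reports. "The series", "measured", "known", "first", "only" and "open" are said of these compounds alone.

Values in an ADME assay (liver) for metabolic stability, with Liver microsome (Homo sapiens) as the target, using microsomes and NADPH, with a stated time of 30 min, tested at 1 uM; on this read-out lower numbers stand for slow clearance and higher numbers for fast clearance:
Compound 1 `Nc1ccc(S(=O)(=O)N2CCN(c3ncc(C(O)(C(F)(F)F)C(F)(F)F)cc3Br)CC2)cn1`: < 14 mL.min-1.g-1, a limit
Compound 2 `Nc1ccc(S(=O)(=O)N2CCN(c3ncc(C(O)(C(F)(F)F)C(F)(F)F)cc3C#CCO)CC2)cn1`: < 14 mL.min-1.g-1, a limit
Compound 3 `Nc1ccc(S(=O)(=O)N2CCN(c3ncc(C(O)(C(F)(F)F)C(F)(F)F)cc3-c3cnccc3F)CC2)cn1`: 17 mL.min-1.g-1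

Among the measured compounds shown here, compound 3, at 17 mL.min-1.g-1, gives the only actual number in this set. The other two results stand at the limit of < 14 mL.min-1.g-1 in this assay, at which 2 of the 3 values shown sit. Compound 4 `COc1ccc(-c2cc(C(O)(C(F)(F)F)C(F)(F)F)cnc2N2CCN(S(=O)(=O)c3ccc(N)nc3)CC2)cn1` has 6-methoxypyridin-3-yl in place of 4-fluoropyridin-3-yl on an aromatic carbon. Two measured steps involve the same place, an at least 1.2-fold higher number from compound 1 to compound 3 (0.08 log units; that floor lies within the scatter) and an at least 1.2-fold higher number from compound 2 to compound 3 (0.08 log units; that floor lies within the scatter). Each has a floor within the scatter, and neither exchanges one pyridinyl group for another. No clear direction follows, so no change beyond the scatter is expected in this assay. The expected step is a 1.2-fold higher number from compound 3 to compound 4 (0.07 log units; within the scatter). Compound 4 is estimated at 20 mL.min-1.g-1, within an expected range of 10 mL.min-1.g-1 to 40 mL.min-1.g-1.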

Compound 4, intrinsic clearance in microsomes: 25 mL.min-1.g-1
Compound 4: the middle estimate sits 1.3-fold (0.10 log units) below what was measured; the measured number falls inside the stated range.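

Two pyridinyl groups can be compared at this position in this assay and the exchange of 4-fluoropyridin-3-yl for 6-methoxypyridin-3-yl gives a 1.5-fold higher number from compound 3 to compound 4 (0.17 log units; within the scatter) so these two groups are not told apart. Against 3-hydroxyprop-1-yn-1-yl and bromo the steps are an at least 1.7-fold higher number from compound 2 to compound 4 (0.25 log units; that floor lies within the scatter) and an at least 1.7-fold higher number from compound 1 to compound 4 (0.25 log units; that floor lies within the scatter) and these floors leave the true size of either change unsettled. Compound 1 and compound 2 each give a limit and not a number: the limit of < 14 mL.min-1.g-1 in this assay, at which 2 of the 4 values shown sit. On these data alone, whether an amine, a morpholine ring or an unsubstituted pyridinyl group at this position would give a step beyond the scatter stays open.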